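A Second Methyl on the Acid Chain

The source may report more compounds than this note shows. Statements on the series, on what has been measured and on what is new or still open speak of the compounds shown alone.

Compound 2 `O=C(O)Cc1nn(Cc2cn3cc(OCC4CC4)c(Cl)cc3n2)c2ccccc2c1=O` carries a carboxymethyl group on the shared core. Among the compounds with values here, in a functional assay on CHO cells for antagonist activity at sphingosine 1-phosphate receptor 2 (Homo sapiens), read by calcium flux (a higher number here means a weaker inhibitor, a lower number a stronger inhibitor), compound 2 gives 20 nM, the lower of the two numbers measured so far, although the gap to its only neighbour is within the scatter. That neighbour, compound 1 `C[C@@H](C(=O)O)c1nn(Cc2cn3cc(OCC4CC4)c(Cl)cc3n2)c2ccccc2c1=O`, gives 24 nM in this assay, and the step of a 1.2-fold lower number from compound 1 to compound 2 (0.08 log units; within the scatter) means the two compounds cannot be told apart. Compound 3 `CC(C)(C(=O)O)c1nn(Cc2cn3cc(OCC4CC4)c(Cl)cc3n2)c2ccccc2c1=O` takes this chain one step further: 1-carboxy-1-methylethyl in place of carboxymethyl on an aromatic carbon. Within the data shown here, the only measured comparison that bears on the change is the step of a 1.2-fold lower number from compound 1 to compound 2 (0.08 log units; within the scatter), which shows that one methyl more or less on that saturated chain carbon did not move the number beyond the scatter. A second methyl is expected to behave much the same, so the expected step is a 1.5-fold higher number from compound 2 to compound 3 (0.18 log units; within the scatter), with no clear direction. Compound 3 is therefore estimated at 30 nM in this assay, within a range from 10 nM to 90 nM.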

Compound 3, half-maximal inhibitory concentration: 7.7 nM
Beside the measured number, compound 3's estimate is 3.9-fold (0.59 log units) above it; measured number outside the range, below it.
By their numbers in this assay, from the lowest: compound 3; then compounds 2 and 1 (each within the scatter of the next).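

In this assay, putting 1-carboxy-1-methylethyl on this aromatic carbon in place of carboxymethyl gives a 2.6-fold lower number from compound 2 to compound 3 (0.41 log units; beyond the scatter) and so shows that the chain carbon can affect the number. Putting the same group in place of 1-carboxyethyl gives a 3.1-fold lower number from compound 1 to compound 3 (0.49 log units; beyond the scatter) as a second step beyond the scatter. The effect of methyl groups here is therefore not even across these three compounds: the single methyl gave only a 1.2-fold lower number from compound 1 to compound 2 (0.08 log units; within the scatter) when removed, and compound 3 alone stands apart.

As far as these compounds go, whether this trend continues with an ethyl group or a cyclopropane ring on that chain carbon, or with a longer chain between the ring and the acid, remains open, as does whether a tetrazole could stand in for the carboxylic acid. No measurement shown here explains why compound 3 differs from the other two.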